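Fluoro in place of chloro on compound 2

The source may hold more compounds than are shown below. What is called first, only, known or untested is meant among the compounds shown, and "the series" means these compounds.

Of the compounds shown here, three have been tested in an ADME assay on MT4 cells (Homo sapiens) for cytotoxicity, read by MTT assay (a lower number here means that less compound is tolerated, a higher number that more compound is tolerated), and none of them has yet given a number. Compound 1 `COc1ccc(C(=O)CSc2nc(Cc3c(Cl)cccc3Cl)cc(=O)[nH]2)cc1` reads > 11000 nM, which is a limit. Compound 2 `COc1ccc(C(=O)CSc2nc(Cc3c(Cl)cccc3Cl)c(C)c(=O)[nH]2)cc1` reads > 56000 nM, which is also a limit. Compound 3 `COc1ccc(C(=O)CSc2nc(Cc3c(Cl)cccc3Cl)c(C(C)C)c(=O)[nH]2)cc1` reads > 14000 nM, again a limit. Compound 2 therefore stands on a limit alone, as do the other two.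

Compound 4 `COc1ccc(C(=O)CSc2nc(Cc3c(F)cccc3Cl)c(C)c(=O)[nH]2)cc1` departs from compound 2 by a single change: fluoro in place of chloro on an aromatic carbon. This is fluoro in place of chloro on an aromatic carbon, ortho to a large group, turning 2,6-dichlorobenzyl into 2-chloro-6-fluorobenzyl.

Within the data shown here, no measured step makes this change. The nearest evidence is methyl or isopropyl exchange at another place: a step that the two limits leave unreadable from compound 1 to compound 2, a step that the two limits leave unreadable from compound 1 to compound 3 and a step that the two limits leave unreadable from compound 2 to compound 3. None of these has a readable size, so none argues for a shift in either direction, and nothing beyond the scatter is expected in this assay.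

The expected outcome is a step that the limit leaves unreadable from compound 2 to compound 4. Compound 4 is estimated at 60000 nM, with an expected range from 15000 nM to 150000 nM.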

Compound 4, half-maximal cytotoxic concentration: > 12000 nM
Compound 4 ended at the assay's limit (the forecaster's own chance of this, stated with the estimate: 75%); the middle value is on the limit's open side.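

Compound 2 and compound 4 both stand at limits of the assay rather than at numbers, and the step between them cannot be read. The compounds shown leave open where any of them would actually reach its half-maximal cytotoxic concentration in this assay, and whether fluoro in place of chloro shifts it at all.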